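Moving the methoxy group of compound 3

This account rests on a few compounds, and the source may have more. Where it says the series, first, only, none or still open, it means among the compounds named here.

Compound 1 `Cc1ccccc1Nc1nc(Nc2ccc(N3CCN(C)CC3)cn2)ncc1Cl`: 5980 nM
Compound 2 `CN1CCN(c2ccc(Nc3ncc(Cl)c(NCc4ccccc4)n3)nc2)CC1`: 20300 nM
Compound 3 `COc1ccc(CNc2nc(Nc3ccc(N4CCN(C)CC4)cn3)ncc2Cl)cc1`: 12900 nM

These three values come from an ADME assay on L02 cells (Homo sapiens) for inhibition, read by CCK-8 assay, with a stated time of 48 h; a higher number here means a weaker inhibitor of growth, a lower number a stronger inhibitor of growth. Compound 3 has one close neighbour and one further off. The close one shows a 1.6-fold lower number from compound 2 to compound 3 (0.20 log units; within the scatter). The other shows a 2.2-fold higher number from compound 1 to compound 3 (0.33 log units; beyond the scatter).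

Compound 4 `COc1ccccc1CNc1nc(Nc2ccc(N3CCN(C)CC3)cn2)ncc1Cl` has the same atoms as compound 3, joined differently: 2-methoxyphenyl in place of 4-methoxyphenyl on a saturated chain carbon bound to a nitrogen on an aromatic ring.

Among the compounds with values here, no measured step moves a methoxy group, so the evidence is indirect. The nearest guide is the step that puts methoxy in place of hydrogen on an aromatic carbon, which gave a 1.6-fold lower number from compound 2 to compound 3 (0.20 log units; within the scatter). The modest 3.4-fold higher number from compound 1 to compound 2 (0.53 log units; beyond the scatter) comes from a different change, benzyl in place of 2-methylphenyl, and bears on this question only weakly. No step beyond the scatter is therefore expected in this assay.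

The expected change is a 1.1-fold lower number from compound 3 to compound 4 (0.03 log units; within the scatter). For compound 4 the estimated value is 12000 nM, with an expected range of 6000 nM to 24000 nM.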

Compound 4, concentration for 50% growth inhibition: 25500 nM
Beside the measured number, compound 4's estimate is 2.1-fold (0.33 log units) below it, outside the stated range (above it).
By their numbers in this assay, from the lowest: compound 1; then compounds 3, 2 and 4 (each within the scatter of the next).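

Moving the methoxy group from 4-methoxyphenyl to 2-methoxyphenyl gives a 2.0-fold higher number from compound 3 to compound 4 (0.30 log units; within the scatter) in this assay and so does not separate the two placements on this saturated chain carbon. Compound 4 also stays close to the unsubstituted benzyl compound, with a 1.3-fold higher number from compound 2 to compound 4 (0.10 log units; within the scatter) and thus no clear effect of adding methoxy here, while a 4.3-fold higher number from compound 1 to compound 4 (0.63 log units; beyond the scatter) shows that 2-methoxybenzyl, like benzyl and 4-methoxybenzyl, stands apart from the 2-methylphenyl group of compound 1. Nothing available explains these numbers.

The compounds shown leave open whether a group other than methoxy on this benzyl ring, such as an amine or a carboxylic acid, would move the number beyond the scatter from compound 2. From the compounds shown here alone, a longer chain in place of the benzyl carbon also remains untested in these data.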